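Cyclopentyl in Place of Butyl: Expecting a Value for Compound 4

The compounds below may be only part of what the source reports. "The series", "measured", "known", "first", "only" and "open" are said of these compounds alone.

Compound 1 `CN1C(=S)[C@@H](NC(=O)c2nc(Cc3ccccc3)n(C)n2)COc2ccccc21` gives 2.5 nM in a functional assay on HT-29 cells (Homo sapiens) for inhibition, read by luminescence and CellTiter-Glo, with a stated time of 24 h; a lower number here means that less compound is needed, a higher number that more compound is needed for the effect.
Compound 2 `CCCCn1nc(C(=O)N[C@H]2COc3ccccc3N(C)C2=S)nc1Cc1ccccc1` gives 510 nM in this assay.
Compound 3 `CN1C(=S)[C@@H](NC(=O)c2nc(Cc3ccccc3)n(CCCC(F)(F)F)n2)COc2ccccc21` gives 2380 nM in this assay.

Compound 2 stands second highest of the three numbers: the step to its nearest neighbour is a 4.7-fold higher number from compound 2 to compound 3 (0.67 log units; beyond the scatter), and the step from the lowest number is a 200-fold higher number from compound 1 to compound 2 (2.31 log units; beyond the scatter). Compound 4 `CN1C(=S)[C@@H](NC(=O)c2nc(Cc3ccccc3)n(C3CCCC3)n2)COc2ccccc21` differs from compound 2 by cyclopentyl in place of butyl on an aromatic nitrogen. Within the data shown here, the steps that bear on this change are a 200-fold higher number from compound 1 to compound 2 (2.31 log units; beyond the scatter) and a 950-fold higher number from compound 1 to compound 3 (2.98 log units; beyond the scatter), both showing that a saturated chain on this aromatic nitrogen raises the number greatly, and a 4.7-fold higher number from compound 2 to compound 3 (0.67 log units; beyond the scatter), a modest further rise when the chain end changes. Among the measured compounds shown here, no measured step compares a chain with a ring on this nitrogen. Compound 4 is therefore expected to stay close to compound 2, with a step of a 1.4-fold higher number from compound 2 to compound 4 (0.14 log units; within the scatter) not clearly beyond the scatter. Compound 4 is estimated at 700 nM, likely between 150 nM and 3000 nM.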

Compound 4, half-maximal effective concentration: 3530 nM
Estimate against measurement, compound 4: 5.0-fold (0.70 log units) below; measured number outside the range, above it.
By their numbers in this assay, from the lowest: compound 1; then compound 2; then compounds 3 and 4 (each within the scatter of the next).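

In this assay cyclopentyl in place of butyl on this aromatic nitrogen gives a 6.9-fold higher number from compound 2 to compound 4 (0.84 log units; beyond the scatter) and so shows that a ring and an open chain are not interchangeable here. Cyclopentyl in place of 4,4,4-trifluorobutyl gives a 1.5-fold higher number from compound 3 to compound 4 (0.17 log units; within the scatter) so those two groups cannot be told apart, while cyclopentyl in place of methyl gives a 1400-fold higher number from compound 1 to compound 4 (3.15 log units; beyond the scatter) as the largest step at this nitrogen. No measurement shown explains why the ring and the butyl chain differ. Still open, going by these compounds, is how the number changes between methyl and these larger groups, which ethyl or cyclopropyl on this nitrogen could show.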